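From Chloro to Fluoro on One Phenyl Ring

This account rests on a few compounds, and the source may have more. Where it says the series, first, only, none or still open, it means among the compounds named here.

For the measured compounds named here, only two compounds have numbers so far in a functional assay on GBM2 cells (Homo sapiens) for antiproliferative activity, read by WST assay, with a stated time of 72 h (on this read-out higher numbers stand for weaker inhibition and lower numbers for stronger inhibition), and together they give a first, thin picture. Compound 1 (`O=C(Nc1cccc(Cl)c1)Nc1cc2ncncc2cc1OCc1ccccc1Cl`) gives 2100 nM and holds the lower of the two numbers. Compound 2 (`O=C(Nc1cc2ncncc2cc1OCc1ccc(Cl)cc1)Nc1cccc2ccccc12`) gives 4500 nM which is higher by more than the usual scatter of repeated measurements. Going by the values given here, no measured pair yet isolates a single change, so the data do not show how far one small swap can move the number.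

The next compound, compound 3 (`O=C(Nc1cccc(F)c1)Nc1cc2ncncc2cc1OCc1ccccc1Cl`) keeps the structure of compound 1 apart from one substituent. It carries fluoro in place of chloro on an aromatic carbon, which turns 3-chlorophenyl into 3-fluorophenyl (fluoro in place of chloro on an aromatic carbon) and leaves the rest untouched.

Among the compounds with values here, with no measured step to go on, only a slight move toward a higher number is expected, and it should stay within the scatter, with the estimated change being a 1.3-fold higher number from compound 1 to compound 3 (0.12 log units; within the scatter) in this comparison. For compound 3 the estimated value is 2800 nM with an expected range from 1200 nM to 6500 nM in this assay once it is measured.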

Compound 3, half-maximal inhibitory concentration: 3200 nM
For compound 3 the middle estimate is 1.1-fold (0.06 log units) below the measured one; the measured number falls inside the stated range.
By their numbers in this assay, from the lowest: compounds 1, 3 and 2 (each within the scatter of the next, the first and the last beyond it).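

For the compounds shown here, this is the first pair of compounds that isolates a single change. In this assay, putting fluoro in place of chloro on the aromatic carbon of the 3-chlorophenyl group gives a 1.5-fold higher number from compound 1 to compound 3 (0.18 log units; within the scatter) and so stays within the usual scatter of repeated measurements. At this one place, then, the two halogens cannot be told apart in this read-out, and this single swap gives no sign that the chlorine itself matters for the number. Nothing is available here that would explain this result or tie it to any property of either halogen.

Going by these compounds, only two halogens have been compared at this place, so it remains open whether a different kind of group there, such as an amine, a methoxy or a carboxylic acid, would move the number beyond the scatter. Also open, on these data alone, is how much a single change elsewhere in the molecule would matter, since compound 2 differs from compound 1 in more than one place and cannot separate the effect of any one of its changes.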